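This account rests on a few compounds, and the source may have more. Where it says the series, first, only, none or still open, it means among the compounds named here.

Of the compounds shown here, three share one core and have been tested in a functional assay on T47D cells (Homo sapiens) for inhibition, read by sulforhodamine B assay, with a stated time of 48 h; on this read-out higher numbers stand for weaker inhibition of growth and lower numbers for stronger inhibition of growth. Compound 2 `CC(=O)OC/C(=C/c1ccccc1Cl)C(=O)c1ccccc1` gives 19000 nM. Compound 3 `CC(=O)OC/C(=C/c1ccccc1Br)C(=O)c1ccccc1` gives 18000 nM, and compound 1 `CC(=O)OC/C(=C\c1ccc(Cl)cc1Cl)C(=O)c1ccccc1` gives 9500 nM. Compound 2 thus shows the highest of the three numbers, with compound 3 closest and compound 1 furthest away, yet both gaps stay within the usual scatter of this assay.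

Compound 4 `CC(=O)OC/C(=C/c1ccc(Cl)cc1Cl)C(=O)c1ccccc1` has not been measured. Compared with compound 2, its change is chloro in place of hydrogen on an aromatic carbon, placed on an aromatic carbon of a six-membered aromatic ring of carbon only, meta to a chloro group and para to a large group.

For the measured compounds named here, only one measured step exists, and it concerns a different change: a 1.1-fold lower number from compound 2 to compound 3 (0.02 log units; within the scatter). Going by the values given here, no step isolates an added chloro at this place. Compound 1 carries two chloro groups like compound 4, but differs from compound 2 in more than one respect, so its value only shows that the two numbers lie close together.

On this thin basis, the step from compound 2 to compound 4 in this assay is expected to be small, a 1.6-fold lower number from compound 2 to compound 4 (0.20 log units; within the scatter), with no change beyond the scatter clearly foreseeable. Compound 4 is therefore estimated at 12000 nM, within a range from 5000 nM to 30000 nM.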

Compound 4, concentration for 50% growth inhibition: 20000 nM
Compound 4: middle estimate off by 1.7-fold (0.22 log units), on the low side; the measured number falls inside the stated range.
By their numbers in this assay, from the lowest: compounds 1, 3, 2 and 4 (each within the scatter of the next, the first and the last beyond it).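

In this assay, a chloro in place of hydrogen at this place, meta to the chloro group already present and para to a large group, gives a step that cannot be told apart from the scatter: a 1.1-fold higher number from compound 2 to compound 4 (0.02 log units; within the scatter). The other new comparison is the only one of the two that clears the scatter, and it is modest: a 2.1-fold higher number from compound 1 to compound 4 (0.32 log units; beyond the scatter). With both chloro groups present, the drawn configuration of the double bond therefore separates two compounds that the added chloro alone did not separate from compound 2, and this step can be assigned to that configuration because nothing else varies, as shown by this: the fact that compounds 1 and 4 differ only in the configuration as drawn

Whether the double bond configuration gives a similar step with a single chloro or bromo group remains open, since the compounds shown offer such a pair only for the two chloro groups. Going by these compounds, it is also open whether a different group at this place, such as an amine, a carboxylic acid or a methoxy group, would give a step beyond the scatter, and whether it would do so with either configuration of the double bond.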